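The source may report more compounds than this note shows. Statements on the series, on what has been measured and on what is new or still open speak of the compounds shown alone.

- Compound 1 `OC[C@H]1O[C@@H](n2cnc3c(NCc4ccc(Cl)cc4)ncnc32)[C@H](O)[C@@H]1O`: > 166000 nM (a limit)
- Compound 2 `COc1ccccc1CNc1ncnc2c1ncn2[C@@H]1O[C@H](CO)[C@@H](O)[C@H]1O`: > 166000 nM (a limit)

In a functional assay on MCF cells (Homo sapiens) for antiproliferative activity, with a stated time of 72 h (on this read-out higher numbers stand for weaker inhibition and lower numbers for stronger inhibition), compound 2 gives > 166000 nM as a limit of the assay and not as a number. The same holds for both measured compounds, as the limit of > 166000 nM in this assay, at which 2 of the 2 values shown sit, shows. Compound 3 `COc1cccc(CNc2ncnc3c2ncn3[C@@H]2O[C@H](CO)[C@@H](O)[C@H]2O)c1OC` has not yet been measured. It carries one change from compound 2: methoxy in place of hydrogen on an aromatic carbon. This puts methoxy in place of hydrogen on an aromatic carbon, turning 2-methoxyphenyl into 2,3-dimethoxyphenyl. Going by the values given here, the one measured step that bears on this also alters the groups on that ring, a step that the two limits leave unreadable from compound 1 to compound 2, and it has no readable size. Among the compounds with values here, with that step as the only guide, no step beyond the scatter is expected in this assay. The expected step is a step that the limit leaves unreadable from compound 2 to compound 3 in size. For compound 3 the estimate is 170000 nM, with an expected range from 80000 nM to 350000 nM as its ends.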

Compound 3, half-maximal inhibitory concentration: > 166000 nM
Compound 3 was reported as a limit; the forecaster's own chance of this, stated with the estimate: 85%; the middle value is on the limit's open side.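

No step can be read among compound 1, compound 2 and compound 3, since each result is a limit and not a number: the limit of > 166000 nM in this assay, at which 3 of the 3 values shown sit.

The compounds shown leave open whether any of these ring changes affects antiproliferative activity, and how far each compound lies beyond that limit.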